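Added methoxy on an aromatic carbon: working notes

This account rests on a few compounds, and the source may have more. Where it says the series, first, only, none or still open, it means among the compounds named here.

Measured so far:
Compound 1, `COc1ccc(CN(c2cc(OC)c(OC)c(OC)c2)S(=O)(=O)c2ccc(C)cc2)cc1`: in a functional assay on MGC-803 cells (Homo sapiens) for inhibition, read by MTT assay, with a stated time of 48 h (a higher number here means a weaker inhibitor, a lower number a stronger inhibitor), compound 1 gives 4340 nM.
Compound 2, `COc1cc(N(Cc2ccccc2)S(=O)(=O)c2ccc(C)cc2)cc(OC)c1OC`: in this assay compound 2 gives 3570 nM.
Compound 3, `COc1ccc(N(Cc2nc3ccccc3[nH]2)S(=O)(=O)c2ccc(C)cc2)cc1`: in this assay compound 3 gives only a limit, > 50000 nM.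

The change from compound 2 to compound 1 is methoxy in place of hydrogen on an aromatic carbon, and its step in this assay is a 1.2-fold higher number from compound 2 to compound 1 (0.08 log units; within the scatter). Compound 4, `COc1ccc(N(Cc2nc3ccccc3[nH]2)S(=O)(=O)c2ccc(C)cc2)cc1OC`, is not yet measured; it arises from compound 3 by methoxy in place of hydrogen on an aromatic carbon. This is the same kind of change, not the same: in compound 1 the entering methoxy sits para to a large group, in compound 4 it sits ortho to a methoxy group and meta to a large group. How the core of compound 3 differs from that of compound 2 is not broken down here.

Compound 3 sits at the limit of > 50000 nM in this assay, at which 1 of the 3 values shown sits, so its number is not known. From the earlier step the added methoxy is expected to move the number little, and compound 4 is expected near the same limit, with the step that the limit leaves unreadable from compound 3 to compound 4 carrying wide uncertainty. The estimate for compound 4 in this assay is 70000 nM, between 20000 nM and 250000 nM.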

Compound 4, half-maximal inhibitory concentration: > 50000 nM
Compound 4: only a limit was reported; the forecaster's own chance of this, stated with the estimate: 70%; the middle value lies beyond the limit too.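

In this assay the step from compound 3 to compound 4 cannot be read, since each of the two compounds gives only a limit and not a number: the limit of > 50000 nM in this assay, at which 2 of the 4 values shown sit.

The compounds shown leave open whether methoxy in place of hydrogen on an aromatic carbon moves the number at all on the core of compound 3.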